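From a hydroxyethyl chain to an anilinopropyl chain

The compounds below may be only part of what the source reports. "The series", "measured", "known", "first", "only" and "open" are said of these compounds alone.

Compound 1 `CCN(CC)CCn1c(N)c(-c2nc3ccccc3[nH]2)c2nc(C#N)c(C#N)nc21` gives 1880 nM in a functional assay on HL-60 cells (Homo sapiens) for antiproliferative activity, read by MTT assay, with a stated time of 48 h; on this read-out lower numbers stand for stronger inhibition and higher numbers for weaker inhibition. For compound 2 `N#Cc1nc2c(-c3nc4ccccc4[nH]3)c(N)n(CCO)c2nc1C#N` this assay reports only a limit, > 50000 nM. Compound 2 therefore stands at the limit of > 50000 nM in this assay, at which 1 of the 2 values shown sits. Among the compounds with values here, the one step between measured compounds, an at least 26-fold higher number from compound 1 to compound 2 (1.42 log units; beyond the scatter), shows that replacing the diethylamino with hydroxy cost a large amount of activity. Compound 3 `N#Cc1nc2c(-c3nc4ccccc4[nH]3)c(N)n(CCCNc3ccccc3)c2nc1C#N` differs from compound 2 by anilinomethyl in place of hydroxy on a saturated chain carbon, two bonds along the chain from an aromatic nitrogen. Within the data shown here, only the step from compound 1 to compound 2 bears on this change, and it points in the opposite direction: a hydroxy on that chain carbon went with the weakest result, while a nitrogen substituent went with the strongest. Bringing a nitrogen back, here as an aniline on a longer chain, is expected to give a step of an at least 5.0-fold lower number from compound 2 to compound 3 (0.69 log units; beyond the scatter) toward stronger inhibition. Compound 3 is estimated at 10000 nM, with a range from 2000 nM to 50000 nM.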

Compound 3, half-maximal inhibitory concentration: 6920 nM
Estimate against measurement, compound 3: 1.4-fold (0.16 log units) above, and the stated range covers the measured number.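

In this assay, a nitrogen on the chain restores activity even when it carries an aromatic ring, with an at least 7.2-fold lower number from compound 2 to compound 3 (0.85 log units; beyond the scatter). The recovery is only partial, however, with a 3.7-fold higher number from compound 1 to compound 3 (0.57 log units; beyond the scatter), so the anilinomethyl group does not reach what the diethylamino group gave at this position. The first of these steps gives only a minimum size, as the value for compound 2 is a limit and not a number: the limit of > 50000 nM in this assay, at which 1 of the 3 values shown sits.

Going from 2-hydroxyethyl to 3-anilinopropyl changes the end group and the chain length together, which leaves open how much of the gain belongs to the aniline nitrogen, the aromatic ring or the longer chain. Also open, as far as these compounds go, is how a diethylamino group on the longer chain, or a morpholine or carboxylic acid at the chain end, would read in this assay.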